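A few compounds are considered here, and "the series" means these few. Any claim that something is new, unique, unknown or untested is made for them only; others in the source may bear on it.

Two compounds of this series share one core. Compound 1, `CN1CCN(c2ccc(C3=NN(C(=O)c4ccc(C(F)(F)F)cc4)C(c4ccc(N(C)C)cc4)C3)cc2)CC1`, reaches 93.2% in a functional assay on NCI-H1975 cells (Homo sapiens) for inhibition, read by sulforhodamine B assay, tested at 10 uM; on this read-out lower numbers stand for less inhibition and higher numbers for more inhibition at the one concentration tested (going by the name of the read-out). Going by the values given here, compound 2, `CN(C)c1ccc(C2CC(c3ccc(-n4cncn4)cc3)=NN2C(=O)c2ccc(C(F)(F)F)cc2)cc1`, gives 11.5% in this assay; this is the lower of the two numbers, and the single measured step, a number 81.7 percentage points lower from compound 1 to compound 2 (beyond the scatter), separates it from compound 1. Compound 3, `CN(C)c1ccc(C2CC(c3ccc(-n4cncn4)cc3)=NN2S(=O)(=O)c2ccc(C#N)cc2)cc1`, has not yet been measured. It differs from compound 2 in one place: (4-cyanophenyl)sulfonyl in place of (4-(trifluoromethyl)phenyl)carbonyl on an amine nitrogen in a ring. Among the compounds with values here, no measured step touches this position. Within the data shown here, the only step known concerns the group on an aromatic carbon, not the group on the amine nitrogen in the ring, so it gives no guide to the size or direction of this change. Compound 2 already sits low, which leaves little room beneath it, and nothing in the data points to a rise. The expected step is therefore a number 3.5 percentage points higher from compound 2 to compound 3 (within the scatter), within the usual scatter. Compound 3 is estimated at 15% in this assay, with a likely range from 0% to 45%, pending the actual measurement.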

Compound 3, a percentage reported as inhibition, at one concentration (the size of the read-out at that concentration, not a potency): 22.6%
Beside the measured number, compound 3's estimate is 7.6 percentage points below it; low and high end bracket the measured number.
By their numbers in this assay, from the lowest: compound 2; then compound 3; then compound 1.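

In this assay, going by these compounds alone, the first measured change on the amine nitrogen in the ring, (4-cyanophenyl)sulfonyl in place of (4-(trifluoromethyl)phenyl)carbonyl, gives a modest step (a number 11.1 percentage points higher from compound 2 to compound 3 (beyond the scatter)), so this position does affect the read-out even with the 4-(1H-1,2,4-triazol-1-yl)phenyl group in place. The exchange alters two things at once, the carbonyl link becoming a sulfonyl and the trifluoromethyl on the aromatic ring becoming a nitrile, and this single step cannot be divided between them. Nothing measured here gives a reason for the step.

Still open, going by these compounds, is how a (4-(trifluoromethyl)phenyl)sulfonyl group or a (4-cyanophenyl)carbonyl group would read on the same nitrogen, since either would separate the effect of the link from that of the substituent on the aromatic ring. Within the data shown here, also open is whether the (4-cyanophenyl)sulfonyl group would shift the number in the same direction alongside the 4-methylpiperazin-1-yl group, the one feature that sets compound 1 (93.2%) apart from compound 2.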